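The source may report more compounds than this note shows. Statements on the series, on what has been measured and on what is new or still open speak of the compounds shown alone.

Measured compounds and their numbers:

Compound 1, `COc1cccc(-c2c(C)n(Cc3c(F)cccc3F)c(=O)n(C[C@H](C)NCc3ccccc3)c2=O)c1F`, gives 51 nM in an assay on HEK293 cells for binding affinity to Gonadotropin-releasing hormone receptor (Homo sapiens), read by radioligand binding; on this read-out higher numbers stand for weaker inhibition and lower numbers for stronger inhibition.
Compound 2, `COc1cccc(-c2c(C)n(Cc3c(F)cccc3F)c(=O)n(C[C@@H](N)C3CCCC3)c2=O)c1F`, gives 94 nM in this assay.
Compound 3, `COc1cccc(-c2c(C)n(Cc3c(F)cccc3F)c(=O)n(C[C@H](NC(C)C)C3CCCCC3)c2=O)c1F`, gives 23 nM in this assay.

Compound 2 shows the highest of the three numbers. Its gap to compound 1, a 1.8-fold higher number from compound 1 to compound 2 (0.27 log units; within the scatter), is within the scatter, so these two cannot be told apart. Only compound 3 is clearly separated, through a 4.1-fold lower number from compound 2 to compound 3 (0.61 log units; beyond the scatter).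

Compound 4, `COc1cccc(-c2c(C)n(Cc3c(F)cccc3F)c(=O)n(C[C@@H](C3CCCCC3)N(C)C)c2=O)c1F`, is the compound still to be measured. It differs from compound 2 by cyclohexyl(dimethylamino)methyl in place of amino(cyclopentyl)methyl on a saturated chain carbon bound to an aromatic nitrogen. The closest measured step is a 4.1-fold lower number from compound 2 to compound 3 (0.61 log units; beyond the scatter), where the five-membered ring became six-membered and the amine gained one alkyl group; the related step of a 2.2-fold lower number from compound 1 to compound 3 (0.35 log units; beyond the scatter) points the same way. Going by the values given here, no measured step shows an amine with two methyl groups and no hydrogen-bond donor, so that part of the change is untested.

On that basis a step of about a 3.1-fold lower number from compound 2 to compound 4 (0.50 log units; beyond the scatter) is expected for compound 4 in this assay. The estimate for compound 4 is 30 nM, expected to fall between 10 nM and 90 nM.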

Compound 4, inhibition constant: 4.1 nM
Beside the measured number, compound 4's estimate is 7.3-fold (0.86 log units) above it, outside the stated range (below it).
By their numbers in this assay, from the lowest: compound 4; then compound 3; then compounds 1 and 2 (each within the scatter of the next).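

Swapping only the amine while keeping the cyclohexyl group gives a 5.6-fold lower number from compound 3 to compound 4 (0.75 log units; beyond the scatter) in this assay, so at this position an amine without a hydrogen-bond donor, dimethylamino, is not merely tolerated but goes with stronger inhibition than isopropylamino. Going by these compounds alone, the wider comparisons are larger still, with a 23-fold lower number from compound 2 to compound 4 (1.36 log units; beyond the scatter) and a 12-fold lower number from compound 1 to compound 4 (1.09 log units; beyond the scatter), which makes compound 4 the strongest of the four, clearly separated from each of the others, and shows that this side chain has far more influence on the read-out than the earlier compounds revealed. No measurement shown here explains why the dimethylamino compound stands out.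

From the compounds shown here alone, the step from compound 2 changes both the ring and the amine at once, so the share belonging to each remains open, and a cyclopentyl group carrying dimethylamino would help separate them. Going by these compounds, it is also open whether the gain is particular to dimethylamino or extends to a slightly larger amine such as diethylamino.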